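Swapping the Chain End of Compound 3 for Sulfanyl

The compounds below may be only part of what the source reports. "The series", "measured", "known", "first", "only" and "open" are said of these compounds alone.

Three compounds share one core and differ only in the length of a chain ending in hydroxycarbamoyl: compound 1 `Cn1cc(-c2ccc(=O)n(CCOc3ccnc4cc(OCCCC(=O)NO)ccc34)n2)cn1`, compound 2 `Cn1cc(-c2ccc(=O)n(CCOc3ccnc4cc(OCCCCCC(=O)NO)ccc34)n2)cn1` and compound 3 `Cn1cc(-c2ccc(=O)n(CCOc3ccnc4cc(OCCCCCCC(=O)NO)ccc34)n2)cn1`. In a functional assay on EBC-1 cells (Homo sapiens) for antiproliferative activity, read by sulforhodamine B assay, with a stated time of 72 h (a lower number here means a stronger inhibitor, a higher number a weaker inhibitor), compound 1 gives 870 nM, compound 2 gives 460 nM and compound 3 gives 210 nM. Compound 3 therefore has the lowest number of the three. Lengthening the chain gave a 1.9-fold lower number from compound 1 to compound 2 (0.28 log units; within the scatter), then a 2.2-fold lower number from compound 2 to compound 3 (0.34 log units; beyond the scatter), and over the whole set a 4.1-fold lower number from compound 1 to compound 3 (0.62 log units; beyond the scatter).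

Compound 4 `Cn1cc(-c2ccc(=O)n(CCOc3ccnc4cc(OCCCCCS)ccc34)n2)cn1` changes the end of the chain instead: sulfanyl in place of (hydroxycarbamoyl)methyl on a saturated chain carbon, five bonds along the chain from an oxygen on an aromatic ring. Sulfanyl stands in place of (hydroxycarbamoyl)methyl, five bonds along the chain from an oxygen on an aromatic ring.

Going by the values given here, every measured compound carries hydroxycarbamoyl, so no measured step shows what removing it does, and the chain steps bear on this change only indirectly. Among the compounds with values here, with compound 3 at 210 nM, the lowest number so far, a move upward in this assay seems likelier than a further fall, and its size is uncertain. The expected change is a 2.9-fold higher number from compound 3 to compound 4 (0.46 log units; beyond the scatter). For compound 4 the estimated value is 600 nM, with an expected range of 170 nM to 2200 nM.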

Compound 4, half-maximal inhibitory concentration: 640 nM
Beside the measured number, compound 4's estimate is 1.1-fold (0.03 log units) below it, within the range that was stated.
By their numbers in this assay, from the lowest: compound 3; then compounds 2, 4 and 1 (each within the scatter of the next).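

Compound 4 is the only compound shown without hydroxycarbamoyl, and in this assay it still has a measurable effect on the cells, so a number in this range does not depend on that group being at the chain end. Against the lowest number of the series the change costs something, with a 3.0-fold higher number from compound 3 to compound 4 (0.48 log units; beyond the scatter) as the step, yet the two shorter hydroxycarbamoyl chains cannot be separated from the sulfanyl chain, with a 1.4-fold higher number from compound 2 to compound 4 (0.14 log units; within the scatter) and a 1.4-fold lower number from compound 1 to compound 4 (0.13 log units; within the scatter) as the steps, so sulfanyl on this chain reads like hydroxycarbamoyl on a shorter one. Nothing shown here gives a measured reason for these differences.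

Among the compounds shown, sulfanyl appears at one chain length only, so it stays open whether a longer chain ending in sulfanyl would bring the number down as lengthening did for the hydroxycarbamoyl chains. On these data alone, it also stays open how a carboxylic acid or an amine at the same place, on a saturated chain carbon, would compare with either end group.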